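A Methoxyphenyl Amide in Place of a Chlorophenyl One

This account rests on a few compounds, and the source may have more. Where it says the series, first, only, none or still open, it means among the compounds named here.

In a functional assay on A549 cells (Homo sapiens) for antiproliferative activity, read by BrdU incorporation, with a stated time of 24 h (on this read-out higher numbers stand for weaker inhibition and lower numbers for stronger inhibition), compound 1 `O=C(CN1CCN(c2cc3c(cc2F)c(=O)c(C(=O)O)cn3C2CC2)CC1)Nc1ccccc1` reports only a limit, > 100000 nM. Going by the values given here, compound 2 `O=C(CN1CCN(c2cc3c(cc2F)c(=O)c(C(=O)O)cn3C2CC2)CC1)Nc1ccc(Cl)cc1` gives 14800 nM, the only number recorded in this assay, since the other value sits at the limit of > 100000 nM in this assay, at which 1 of the 2 values shown sits. Among the compounds with values here, the single measured step is an at least 6.7-fold lower number from compound 1 to compound 2 (0.82 log units; beyond the scatter). Compound 3 `COc1ccccc1NC(=O)CN1CCN(c2cc3c(cc2F)c(=O)c(C(=O)O)cn3C2CC2)CC1` differs from compound 2 by 2-methoxyphenyl in place of 4-chlorophenyl on an amide-type nitrogen. Within the data shown here, no measured step involves a methoxy group, so the chloro step offers only a loose guide; a similar or weaker value is expected, with a step of a 2.0-fold higher number from compound 2 to compound 3 (0.31 log units; beyond the scatter). Compound 3 is therefore estimated at 30000 nM, between 8000 nM and 100000 nM.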

Compound 3, half-maximal inhibitory concentration: > 100000 nM
Compound 3 ended at the assay's limit; the forecaster's own chance of this, stated with the estimate: 30%; at least 3.3-fold (0.52 log units) between middle value and limit.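

In this assay, replacing 4-chlorophenyl with 2-methoxyphenyl on the amide-type nitrogen gives an at least 6.7-fold higher number from compound 2 to compound 3 (0.82 log units; beyond the scatter), leaving the 4-chlorophenyl amide as the only one of the three with a readable number. Compound 3 reports only a limit, > 100000 nM. The step from compound 1 to compound 3 cannot be read, so methoxy cannot be ranked against hydrogen, and the comparison rests on a single number: the limit of > 100000 nM in this assay, at which 2 of the 3 values shown sit.

From the compounds shown here alone, the group and its place on the ring change together here, so which of the two matters stays open. Going by these compounds, what an amine or a nitrile would do on this ring also stays open.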